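The compounds below may be only part of what the source reports. "The series", "measured", "known", "first", "only" and "open" are said of these compounds alone.

- Compound 1 `O=C(N/N=C/c1cccc(Br)c1)c1ccc([N+](=O)[O-])o1`: "not determined" (no result reported)
- Compound 2 `O=C(N/N=C/c1ccc([N+](=O)[O-])o1)c1ccc([N+](=O)[O-])o1`: 213000 nM
- Compound 3 `C/C(=N\NC(=O)c1ccc([N+](=O)[O-])o1)c1ccccc1`: > 228000 nM

These compounds belong to a small set examined in an ADME assay on Vero cells (Chlorocebus sabaeus) for cytotoxicity, read by MTT assay, with a stated time of 72 h; on this read-out lower numbers stand for higher toxicity in this test and higher numbers for lower toxicity in this test. Compound 1 has no reported result, so it offers no guide here. For the measured compounds named here, compound 2 gives 213000 nM, the only plain number in the set. Compound 3 gives > 228000 nM, and this is a limit of the assay, not a number. Going by the values given here, compound 3 therefore has no exact position, and no measured pair shows how a single structural change acts in this assay.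

Compound 4 `C/C(=N\NC(=O)c1ccc([N+](=O)[O-])o1)c1ccc(F)cc1` keeps the structure of compound 3 except for one change: fluoro in place of hydrogen on an aromatic carbon, para to a large group (fluoro in place of hydrogen on an aromatic carbon). In other words, phenyl becomes 4-fluorophenyl. Among the compounds with values here, with no measured step to draw on, the expectation is that this small change will not move the result beyond the usual scatter, in either direction. The estimated step of an at least 1.0-fold lower number from compound 3 to compound 4 (0.03 log units; that floor lies within the scatter) reflects that expectation. The expectation starts from compound 3 at > 228000 nM. Compound 4 may also be reported only as a limit. Compound 4 is expected at 210000 nM, with an estimated range from 100000 nM to 300000 nM.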

Compound 4, half-maximal cytotoxic concentration: 215000 nM
Compound 4: the middle estimate sits 1.0-fold (0.01 log units) below what was measured; measured number inside the range.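

For the compounds shown here, replacing phenyl with 4-fluorophenyl gives the first step that can be read in this assay, with an at least 1.0-fold lower number from compound 3 to compound 4 (0.02 log units; that floor lies within the scatter) as the result. Going by these compounds alone, this gives the set a first look at the fluoro group at this place, para to a large group: the step as printed does not go beyond the usual scatter, but it is only a floor, so a larger true step is not ruled out. On these data alone, the true size of the step stays unknown because compound 3 carries a limit of the assay and not a number: the limit of > 228000 nM in this assay, at which 1 of the 4 values shown sits.

The compounds shown leave open whether another group at this same place, such as a chlorine atom, a methoxy group or an amine, would move the number beyond the scatter, and whether a fluoro group elsewhere on the ring would behave as it does here. They also do not show how a longer chain in place of the methyl group of compound 3 would read in this assay.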